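From 2-chloro-4-fluorophenyl to 4-methoxyphenyl: what to expect

A few compounds are considered here, and "the series" means these few. Any claim that something is new, unique, unknown or untested is made for them only; others in the source may bear on it.

Measured so far in a functional assay on A549 cells (Homo sapiens) for cytotoxicity, read by MTT assay, with a stated time of 72 h; a lower number here means a stronger inhibitor, a higher number a weaker inhibitor:
- Compound 1 `CNC(=O)c1cc(Oc2ccc(C(=O)/C=C/c3cccc(Br)c3)cc2)ccn1` gives 9940 nM
- Compound 2 `CNC(=O)c1cc(Oc2ccc(C(=O)/C=C/c3ccc([N+](=O)[O-])cc3)cc2)ccn1` gives > 50000 nM, a limit of the assay and not a number
- Compound 3 `CNC(=O)c1cc(Oc2ccc(C(=O)/C=C/c3ccc(F)cc3Cl)cc2)ccn1` gives 21100 nM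

Compound 3, at 21100 nM, has the higher of the two true numbers. The gap to its nearest neighbour is a 2.1-fold higher number from compound 1 to compound 3 (0.33 log units; beyond the scatter).

Compound 4 `CNC(=O)c1cc(Oc2ccc(C(=O)/C=C/c3ccc(OC)cc3)cc2)ccn1` carries 4-methoxyphenyl in place of 2-chloro-4-fluorophenyl on a double-bonded chain carbon bound to a double-bonded chain carbon.

All three measured steps change the group at this same place, so all three bear on this one. Compound 2 sits on the far side of the other two, with an at least 5.0-fold higher number from compound 1 to compound 2 (0.70 log units; beyond the scatter) and an at least 2.3-fold lower number from compound 2 to compound 3 (0.37 log units; beyond the scatter). Within the data shown here, no compound with a 4-methoxyphenyl group has been measured, so the direction cannot be read from the data.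

The expected change is small, and the estimated step is a 1.1-fold higher number from compound 3 to compound 4 (0.06 log units; within the scatter). For compound 4 the estimated value is 24000 nM, with an expected range from 9000 nM to 50000 nM.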

Compound 4, half-maximal inhibitory concentration: > 50000 nM
Compound 4 ended at the assay's limit; the forecaster's own chance of this, stated with the estimate: 25%; middle value at least 2.0-fold (0.31 log units) away from the limit.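

Compound 4 shows that this place does not tolerate every group of similar size in this assay, with an at least 2.3-fold higher number from compound 3 to compound 4 (0.37 log units; beyond the scatter) and an at least 5.0-fold higher number from compound 1 to compound 4 (0.70 log units; beyond the scatter). Among the four compounds, only the halogen-bearing groups, 3-bromophenyl in compound 1 and 2-chloro-4-fluorophenyl in compound 3, give true numbers, and neither 4-nitrophenyl nor 4-methoxyphenyl goes against this pattern. The step from compound 2 to compound 4 cannot be read because both values are limits of the assay and not numbers: the limit of > 50000 nM in this assay, at which 2 of the 4 values shown sit.

From the compounds shown here alone, it remains open whether the halogen itself matters, which a plain phenyl or a 4-chlorophenyl group at this place could test. It is also unknown how far compound 4 and compound 2 lie from each other, or whether a ring bearing an amine would also end at the limit.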